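Extending the Ester Group of a Calcium Channel Blocker

The compounds below may be only part of what the source reports. "The series", "measured", "known", "first", "only" and "open" are said of these compounds alone.

Three measured compounds share one core and differ in their ester groups. Compound 1 `CCOC(=O)C1=C(C)NC(COC(C)=O)=C(C(=O)OCC)C1c1cccc([N+](=O)[O-])c1` gives 37 nM in a functional assay on HEK293 cells for antagonist activity at Voltage-dependent L-type calcium channel subunit alpha-1D (Rattus norvegicus), read by FLIPR; a higher number here means a weaker inhibitor, a lower number a stronger inhibitor. Compound 2 `C=C(C)C(=O)OCCOC(=O)C1=C(C)NC(C)=C(C(=O)OCC)C1c1cccc([N+](=O)[O-])c1` gives 10 nM in this assay, and compound 3 `COC(=O)C1=C(C)NC(C)=C(C(=O)OCc2ccccc2)C1c1cccc([N+](=O)[O-])c1` gives 15 nM. Compound 3 thus stands second highest of the three: its gap to compound 2 lies within the scatter, while its gap to compound 1 lies beyond it. Compound 4 `COC(=O)C1=C(C)NC(C)=C(C(=O)OCCCCc2ccc(OC)cc2)C1c1cccc([N+](=O)[O-])c1` is not yet measured and differs from compound 3 in one place: 3-(4-methoxyphenyl)propyl in place of phenyl on a saturated chain carbon bound to an oxygen next to a carbonyl group. Within the data shown here, no single-change step between measured compounds is available. Compound 2 gives 10 nM and compound 3 gives 15 nM despite different ester groups, so an ester change alone need not move the number far. For compound 4 the step of a 1.3-fold lower number from compound 3 to compound 4 (0.10 log units; within the scatter) is expected to be small, if any, and not clearly beyond the scatter. The estimate for compound 4 is 12 nM, between 4 nM and 40 nM.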

Compound 4, half-maximal inhibitory concentration: 38 nM
For compound 4 the middle estimate is 3.2-fold (0.50 log units) below the measured one; low and high end bracket the measured number.
By their numbers in this assay, from the lowest: compounds 2 and 3 (each within the scatter of the next); then compounds 1 and 4 (each within the scatter of the next).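

In this assay, 3-(4-methoxyphenyl)propyl in place of phenyl gives a 2.5-fold higher number from compound 3 to compound 4 (0.40 log units; beyond the scatter) as the only single-change step shown, so this ester position does respond to what is built onto it. The response is modest, and compound 4 still gives 38 nM despite the much larger group. Nothing measured here explains the step.

The longer chain and the methoxy group enter together, so the compounds shown cannot separate them. On these data alone, how a plain 4-phenylbutyl ester, or an amine on the chain, would read remains open.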